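The compounds below may be only part of what the source reports. "The series", "measured", "known", "first", "only" and "open" are said of these compounds alone.

Compound 1 `CN(C)CCCOc1c(OCc2ccccc2)cc(O)c2c(=O)cc(-c3ccccc3)oc12` and compound 2 `CN(C)CCCCOc1c(OCc2ccccc2)cc(O)c2c(=O)cc(-c3ccccc3)oc12` share one core and differ only in the chain that carries the dimethylamino group. In a functional assay on MCF7 cells (Homo sapiens) for cytotoxicity, read by MTT assay, with a stated time of 72 h (a higher number here means a weaker inhibitor, a lower number a stronger inhibitor), compound 1 gives 3210 nM and in this assay compound 2 gives 3210 nM; the step of no change at the digits printed from compound 1 to compound 2 (within the scatter) shows that lengthening that chain left the read-out where it was. Compound 2 therefore stands level with compound 1 at the digits shown. Compound 3 `O=c1cc(-c2ccccc2)oc2c(OCCCCN3CCCC3)c(OCc3ccccc3)cc(O)c12` takes the next step from compound 2: pyrrolidin-1-yl in place of dimethylamino on a saturated chain carbon, four bonds along the chain from an oxygen on an aromatic ring. For the measured compounds named here, no measured pair bears directly on exchanging the amine itself; the only measured step, no change at the digits printed from compound 1 to compound 2 (within the scatter), concerns the chain and was flat. Going by the values given here, with no precedent pointing either way, the change from compound 2 to compound 3 is expected to stay within the scatter, estimated as a 1.0-fold lower number from compound 2 to compound 3 (0.00 log units; within the scatter). Compound 3 is accordingly expected to give about 3200 nM in this assay, with a likely range from 1500 nM to 7000 nM.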

Compound 3, half-maximal inhibitory concentration: 1890 nM
The estimate for compound 3 lay 1.7-fold (0.23 log units) above the measured number; measured number inside the range.
By their numbers in this assay, from the lowest: compounds 3, 1 and 2 (each within the scatter of the next).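

In this assay the exchange of the amine itself, pyrrolidin-1-yl in place of dimethylamino, gives a 1.7-fold lower number from compound 2 to compound 3 (0.23 log units; within the scatter) and so adds to the chain step a change at the amine end that also stays inside the scatter. Taken together with the chain change, the exchange gives a 1.7-fold lower number from compound 1 to compound 3 (0.23 log units; within the scatter) and thus still no separation among the three compounds, so neither the chain length nor the ring-closed amine has yet moved the read-out beyond the scatter. No evidence on hand bears on why these values sit so close.

Open, going by these compounds, is whether a larger ring amine such as piperidine or morpholine at the end of this chain would leave the scatter. Also open, on these data alone, is what a longer chain, or a primary amine in place of the tertiary one, would do.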